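Methyl on the shared core: from compound 3 toward compound 4

The source may report more compounds than this note shows. Statements on the series, on what has been measured and on what is new or still open speak of the compounds shown alone.

Measured so far:
compound 1 `CC(=O)c1ccc(Nc2ccnc(-c3ccncc3)n2)cc1` — 37000 nM
compound 2 `CC(=O)c1ccc(Nc2cc(C)nc(-c3ccncc3)n2)cc1` — 6000 nM
compound 3 `CCOC(=O)c1ccc(Nc2ccnc(-c3cccnc3)n2)cc1` — 61000 nM

In a physicochemical assay for solubility, in phosphate buffer (a higher number here means a more soluble compound, a lower number a less soluble compound), compound 1 gives 37000 nM. Within the data shown here, compound 2 carries the change methyl in place of hydrogen on an aromatic carbon on the core of compound 1, and the step of a 6.2-fold lower number from compound 1 to compound 2 (0.79 log units; beyond the scatter) is the one record of this change with a number attached. Compound 3 gives 61000 nM in this assay; the difference between its core and the core of compound 1 is not broken down here, and the values of compound 3 and compound 1 lie within the scatter of each other.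

Compound 4 `CCOC(=O)c1ccc(Nc2cc(C)nc(-c3cccnc3)n2)cc1` is not yet measured. It differs from compound 3 by methyl in place of hydrogen on an aromatic carbon. This is the same kind of change as from compound 1 to compound 2, though the surroundings are not identical: the methyl stands meta to a pyridin-3-yl group in compound 4 and meta to a pyridin-4-yl group in compound 2. Among the measured compounds shown here, on that one recorded step, a step of a 6.1-fold lower number from compound 3 to compound 4 (0.79 log units; beyond the scatter) is expected in this assay, because a 6.2-fold lower number from compound 1 to compound 2 (0.79 log units; beyond the scatter) is the only guide available. Compound 4 is therefore estimated at 10000 nM, with a range from 4000 nM to 25000 nM.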

Compound 4, solubility: 71000 nM
Beside the measured number, compound 4's estimate is 7.1-fold (0.85 log units) below it; measured number above the stated range.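

In this assay, methyl in place of hydrogen on an aromatic carbon gives a 1.2-fold higher number from compound 3 to compound 4 (0.07 log units; within the scatter), a step within the scatter, while the same kind of change gives a 6.2-fold lower number from compound 1 to compound 2 (0.79 log units; beyond the scatter), a step beyond it. This shows that the size of the step recorded on one core did not carry over to the other in this one comparison, but two records give no general rule for the series. The cores of compound 1 and compound 3 differ in more than one place, and no measurement shown accounts for the contrast between the two steps.

The compounds shown leave open which of the differences between the two cores goes with the contrast. They also leave open how the core of compound 3 would respond to an ethyl group, an amine or a carboxylic acid on that same aromatic carbon.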